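Amide nitrogen substituent change in a chromone cinnamamide series

The source may report more compounds than this note shows. Statements on the series, on what has been measured and on what is new or still open speak of the compounds shown alone.

Measured so far:
compound 1 `COc1cccc(NC(=O)/C=C/c2coc3cc(OC)ccc3c2=O)c1` — 39100 nM
compound 2 `Cc1ccccc1NC(=O)/C=C/c1coc2cc(O)ccc2c1=O` — 9320 nM

Both values come from a functional assay (QGY7701 cells, Homo sapiens) for inhibition, read by MTT assay, with a stated time of 48 h; a higher number here means a weaker inhibitor, a lower number a stronger inhibitor. Among the compounds with values here, compound 1 gives the highest number of the two, compound 2 sitting well lower, and the gap between them is beyond the scatter; since the two structures differ in more than one place, no single step is drawn between them.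

Compound 3 `COc1ccc2c(=O)c(/C=C/C(=O)NCc3ccc(F)cc3F)coc2c1` keeps the core of compound 1 and alters only the amide substituent: 2,4-difluorobenzyl in place of 3-methoxyphenyl on an amide-type nitrogen. The 3-methoxyphenyl leaves and a 2,4-difluorobenzyl enters on the amide-type nitrogen. Within the data shown here, no measured pair shows this kind of change, so the direction can only be guessed. The expected step of a 2.0-fold lower number from compound 1 to compound 3 (0.29 log units; within the scatter) is toward a lower number, modest, and may not exceed the scatter. Compound 3 is estimated at 20000 nM, with a range from 5000 nM to 60000 nM.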

Compound 3, half-maximal inhibitory concentration: > 100000 nM
Compound 3: no number, only a limit (the forecaster's own chance of this, stated with the estimate: 10%); at least 5.0-fold (0.69 log units) between middle value and limit.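

In this assay compound 3 gives > 100000 nM, which is a limit of the assay and not a number. Within the data shown here, with the shared core held, the amide-type nitrogen proves sensitive to its substituent: 2,4-difluorobenzyl in place of 3-methoxyphenyl gives an at least 2.5-fold higher number from compound 1 to compound 3 (0.40 log units; beyond the scatter), the first single-place step, and it runs toward weaker inhibition. The full size of this step stays unknown, as it is read against a limit: the limit of > 100000 nM in this assay, at which 1 of the 3 values shown sits.

The step changes the aromatic ring's substituents and adds the benzyl carbon together, so the compounds shown leave open which of these changes matters. An unsubstituted benzyl or a 3-methoxybenzyl on the same nitrogen would separate the two, and a simple alkyl chain there would show whether an aromatic ring is needed at all.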